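The source may hold more compounds than are shown below. What is called first, only, known or untested is meant among the compounds shown, and "the series" means these compounds.

Compound 1 `O=C(/C=C\c1ccccc1)N1N=C(c2ccncc2)OC1c1c[nH]c2ccccc12` is the parent of this small set. In an ADME assay on A549 cells (Homo sapiens) for cytotoxicity, read by MTT assay, with a stated time of 48 h (on this read-out lower numbers stand for stronger inhibition of growth and higher numbers for weaker inhibition of growth), compound 1 gives > 30 ug/mL, which is a limit of the assay rather than a number. Compound 2 `O=C(/C=C\c1cccc(F)c1)N1N=C(c2ccncc2)OC1c1c[nH]c2ccccc12` carries fluoro in place of hydrogen on an aromatic carbon of the same core. In this assay compound 2 gives > 30 ug/mL, again a limit and not a number. The step that the two limits leave unreadable from compound 1 to compound 2 cannot be sized because both of its ends rest on (the limit of > 30 ug/mL in this assay, at which 2 of the 2 values shown sit). Compound 2 thus stands at the limit, where every value shown so far sits, with no number to separate it from compound 1.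

Compound 3 `O=C(/C=C\c1ccc(Cl)cc1Cl)N1N=C(c2ccncc2)OC1c1c[nH]c2ccccc12` has not yet been measured. It differs from compound 2 by 2,4-dichlorophenyl in place of 3-fluorophenyl on a double-bonded chain carbon bound to a double-bonded chain carbon. Within the data shown here, the only measured step, from compound 1 to compound 2, touches the same aromatic ring, but its size is not readable. No step beyond the scatter is known, so no direction can be expected. Compound 3 is expected to give 30 ug/mL in this assay, with a range from 12 ug/mL to 80 ug/mL, most likely reported as a limit again. The step of a number no higher from compound 2 to compound 3 (the limit leaves the size open) is estimated to stay within the scatter.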

Compound 3, concentration for 50% growth inhibition: > 30 ug/mL
Compound 3 ended at the assay's limit; the forecaster's own chance of this, stated with the estimate: 70%; the middle value sits exactly at the limit.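

In this assay compound 3 gives > 30 ug/mL, again a limit of the assay and not a number. Among these compounds, no step linking compound 3 to compound 1 or compound 2 can be read, because each rests on limits at both ends: the limit of > 30 ug/mL in this assay, at which 3 of the 3 values shown sit. The compounds shown leave open whether any aromatic ring change on this chain alters growth inhibition at all.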